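The compounds below may be only part of what the source reports. "The series", "measured", "known", "first", "only" and "open" are said of these compounds alone.

Working notes on the series. The read-out throughout is a functional assay on MV4-11 cells (Homo sapiens) for antiproliferative activity, with a stated time of 6 days, tested at 1.56 uM; on this read-out lower numbers stand for a weaker effect and higher numbers for a stronger effect at the one concentration tested. Among the compounds with values here, compound 1 `CNC(=O)N1CCCc2ccc(NC(=O)c3ccc(-c4ccccc4)cc3)cc21` gives 19.7% in this assay, the lower of the two numbers so far. Compound 2 `CNC(=O)N1CCCc2ccc(NC(=O)c3cccc(-c4cnn(C(C)=O)c4)c3)cc21` gives 33.6% in this assay, a higher reading than compound 1 shows. Compound 3 `CNC(=O)N1CCCc2ccc(NC(=O)c3ccc(-c4ccccn4)cc3)cc21` is not yet measured; it differs from compound 1 in one place: pyridin-2-yl in place of phenyl on an aromatic carbon. Within the data shown here, no measured pair isolates this change, so nothing here tells its size. Compound 3 is expected to move by a number 5.3 percentage points higher from compound 1 to compound 3 (within the scatter), a step that may not exceed the scatter. Compound 3 is estimated at 25% in this assay, within 8% to 45%.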

Compound 3, a percentage reported as inhibition, at one concentration (the size of the read-out at that concentration, not a potency): 32%
The estimate for compound 3 lay 7 percentage points below the measured number; the measured number falls inside the stated range.
By their numbers in this assay, from the lowest: compound 1; then compounds 3 and 2 (each within the scatter of the next).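

In this assay, pyridin-2-yl in place of phenyl, on an aromatic carbon para to a large group, gives a number 12.3 percentage points higher from compound 1 to compound 3 (beyond the scatter). Within the data shown here, this is the first measured pair that isolates a single change, and it shows that this position responds to one ring carbon being exchanged for nitrogen, with a modest step. No measurement bears on the reason for this step. The compounds shown leave open whether pyridin-4-yl at the same place gives a step of similar size. They also leave open how a non-aromatic group there, such as an amine or a carboxylic acid, would read.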